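Benzyl in place of 3,4-dinitrophenyl on an oxygen

The source may hold more compounds than are shown below. What is called first, only, known or untested is meant among the compounds shown, and "the series" means these compounds.

In a functional assay on RS4-11 cells (Homo sapiens) for inhibition, read by CCK-8 assay, with a stated time of 48 h (on this read-out lower numbers stand for stronger inhibition and higher numbers for weaker inhibition), compound 1 `O=C(NCCNS(=O)(=O)c1ccc(-c2ccccc2O[C@H]2CC[C@H](O)CC2)s1)Nc1cc(C(F)(F)F)cc(C(F)(F)F)c1` gives 10100 nM and compound 2 `O=C(NCCNS(=O)(=O)c1ccc(-c2ccccc2O[C@H]2CC[C@@H](O)CC2)s1)Nc1cc(C(F)(F)F)cc(C(F)(F)F)c1` gives 9300 nM. Compound 3 `O=C(NCCNS(=O)(=O)c1ccc(-c2ccccc2Oc2ccc([N+](=O)[O-])c([N+](=O)[O-])c2)s1)Nc1cc(C(F)(F)F)cc(C(F)(F)F)c1` gives 2400 nM, the lowest of the three numbers. Putting 3,4-dinitrophenyl in place of 4-hydroxycyclohexyl on an oxygen on an aromatic ring produced modest steps, a 4.2-fold lower number from compound 1 to compound 3 (0.62 log units; beyond the scatter) and a 3.9-fold lower number from compound 2 to compound 3 (0.59 log units; beyond the scatter). Given (the fact that compounds 1 and 2 differ only in the configuration as drawn), the remaining measured step, a 1.1-fold lower number from compound 1 to compound 2 (0.04 log units; within the scatter), says nothing about the group now being exchanged.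

Compound 4 `O=C(NCCNS(=O)(=O)c1ccc(-c2ccccc2OCc2ccccc2)s1)Nc1cc(C(F)(F)F)cc(C(F)(F)F)c1` carries benzyl in place of 3,4-dinitrophenyl on an oxygen on an aromatic ring. Benzyl keeps one six-membered aromatic ring of carbon only, so a full reversal of a 3.9-fold lower number from compound 2 to compound 3 (0.59 log units; beyond the scatter) is not expected. A small move towards a higher number is expected in this assay, possibly no larger than the scatter. The expected change is a 1.6-fold higher number from compound 3 to compound 4 (0.20 log units; within the scatter). The estimated value for compound 4 is 3800 nM, with an expected range of 1300 nM to 10000 nM.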

Compound 4, half-maximal inhibitory concentration: > 50000 nM
Compound 4 gave a limit, no number; the forecaster's own chance of this, stated with the estimate: 3%; at least 13-fold (1.11 log units) between middle value and limit.
By their numbers in this assay, from the lowest: compound 3; then compounds 2 and 1 (each within the scatter of the next). At a limit, above all of these: compound 4.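

In this assay compound 4 gives > 50000 nM, which is a limit of the assay and not a number. The exchange at this oxygen gives an at least 20-fold higher number from compound 3 to compound 4 (1.31 log units; beyond the scatter), so keeping one six-membered aromatic ring of carbon only did not preserve the read-out, and the choice of group here matters far more than the earlier modest steps showed. Benzyl also falls on the weak side of the 4-hydroxycyclohexyl compounds, with an at least 5.3-fold higher number from compound 2 to compound 4 (0.73 log units; beyond the scatter) and an at least 4.9-fold higher number from compound 1 to compound 4 (0.69 log units; beyond the scatter), so the aromatic ring alone does not account for the lower number of compound 3.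

The compounds shown do not separate the loss of the two nitro groups from the change from a phenyl to a benzyl; a plain phenyl or a 3,4-dinitrobenzyl on this oxygen would tell the two apart. As far as these compounds go, how far compound 4 lies beyond its limit also stays open.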